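The source may report more compounds than this note shows. Statements on the series, on what has been measured and on what is new or still open speak of the compounds shown alone.

Compound 1 `CCCCNc1nc(N)nc2ccn(Cc3ccccc3)c12` stands at the edge of what the assay could report. In an ADME assay on HEK293 cells (Homo sapiens) for cytotoxicity, read by ATP content, with a stated time of 6 h (a lower number here means that less compound is tolerated, a higher number that more compound is tolerated), compound 1 gives > 24000 nM and this is a limit of the assay rather than a measured number. Compound 2 `CCCCNc1nc(N)nc2ccn(CCCc3ccccc3)c12` gives > 24000 nM in this assay and that too is a limit. Compound 3 `CCCCNc1nc(N)nc2ccn(Cc3nccs3)c12` gives > 24000 nM in this assay and that is a limit as well. The steps among them are a step that the two limits leave unreadable from compound 1 to compound 2 and a step that the two limits leave unreadable from compound 1 to compound 3 and a step that the two limits leave unreadable from compound 2 to compound 3 and all three are unreadable because of the limit of > 24000 nM in this assay, at which 3 of the 3 values shown sit. Each of these changes sits on a saturated chain carbon bound to an aromatic nitrogen, and none of them moved a compound off that limit.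

Compound 4 `CCCCNc1nc(N)nc2ccn(Cc3ccccn3)c12` differs from compound 1 at the same place: pyridin-2-yl in place of phenyl on a saturated chain carbon bound to an aromatic nitrogen. Going by the values given here, no measured step tells how large a change at this place is, since every one of them was hidden by the limit. So in this assay no step beyond the usual scatter is expected in either direction. Compound 4 is expected to give 30000 nM with a range from 15000 nM to 60000 nM. That estimate means a step that the limit leaves unreadable from compound 1 to compound 4 and it is expected that compound 4 will again be reported only as a limit.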

Compound 4, half-maximal cytotoxic concentration: > 24000 nM
Compound 4: no number, only a limit; the forecaster's own chance of this, stated with the estimate: 85%; the middle value does not contradict the limit.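

Compound 4 is again reported only as a limit, so no step among compound 1, compound 2, compound 3 and compound 4 can be read, because all four stop at the same edge: the limit of > 24000 nM in this assay, at which 4 of the 4 values shown sit.

The compounds shown leave open whether any of these groups on a saturated chain carbon bound to an aromatic nitrogen changes the result in this assay at all, and by how much.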